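Para substituent changes on the biaryl series

This account rests on a few compounds, and the source may have more. Where it says the series, first, only, none or still open, it means among the compounds named here.

Measured so far in a functional assay on MKN-45 cells (Homo sapiens) for inhibition, with a stated time of 72 h; on this read-out higher numbers stand for weaker inhibition and lower numbers for stronger inhibition:
- compound 1 `COc1ccc(S(=O)(=O)N2CCc3cccc(-c4ccc([N+](=O)[O-])cc4)c32)cc1`: 34 nM
- compound 2 `COc1ccc(S(=O)(=O)N2CCc3cccc(-c4ccc(O)cc4)c32)cc1`: 82.6 nM
- compound 3 `COc1ccc(S(=O)(=O)N2CCc3cccc(-c4ccc(F)nc4)c32)cc1`: 145 nM

Compound 1 gives the lowest number of the three in this assay; compound 2 lies a 2.4-fold higher number from compound 1 to compound 2 (0.39 log units; beyond the scatter) and compound 3 lies a 4.3-fold higher number from compound 1 to compound 3 (0.63 log units; beyond the scatter). Compound 2 and compound 3 are separated only by a 1.8-fold higher number from compound 2 to compound 3 (0.24 log units; within the scatter).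

Compound 4 `COc1ccc(S(=O)(=O)N2CCc3cccc(-c4ccc(N(C)C)cc4)c32)cc1` is not yet measured. It differs from compound 1 by dimethylamino in place of nitro on an aromatic carbon. For the measured compounds named here, the only step that bears directly on it is the replacement of the nitro group in compound 1 by hydroxy in compound 2, which gave a 2.4-fold higher number from compound 1 to compound 2 (0.39 log units; beyond the scatter). Both measured exchanges of the nitro group, including a 4.3-fold higher number from compound 1 to compound 3 (0.63 log units; beyond the scatter), moved the number upward. Because of a 2.4-fold higher number from compound 1 to compound 2 (0.39 log units; beyond the scatter), a modest upward step from compound 1 to compound 4 is expected here, with no basis for anything larger. The expected step for compound 4 is therefore a 2.1-fold higher number from compound 1 to compound 4 (0.31 log units; beyond the scatter). Compound 4 is estimated at 70 nM in this assay, within a range of 25 nM to 200 nM.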

Compound 4, half-maximal inhibitory concentration: 237 nM
For compound 4 the middle estimate is 3.4-fold (0.53 log units) below the measured one, outside the stated range (above it).
By their numbers in this assay, from the lowest: compound 1; then compounds 2, 3 and 4 (each within the scatter of the next, the first and the last beyond it).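

In this assay a third replacement of the nitro group, now by dimethylamino, again raises the number, with a 7.0-fold higher number from compound 1 to compound 4 (0.84 log units; beyond the scatter), so all three exchanges at this place, para to a large group, go the same way and compound 1 stays alone at the low end. The replacements are now partly separated: dimethylamino and hydroxy differ, with a 2.9-fold higher number from compound 2 to compound 4 (0.46 log units; beyond the scatter), whereas the 4-(dimethylamino)phenyl and 6-fluoropyridin-3-yl compounds do not, at a 1.6-fold higher number from compound 3 to compound 4 (0.21 log units; within the scatter). No measurement at hand accounts for these differences.

Still open, on these data alone, is whether any group other than nitro keeps the number as low as in compound 1, for instance a nitrile, a carboxylic acid or a methyl ester at this same place. Also open, as far as these compounds go, is whether a primary amine in place of dimethylamino would sit nearer compound 1 or compound 4.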